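A diethylamino swap on compound 2

The compounds below may be only part of what the source reports. "The series", "measured", "known", "first", "only" and "open" are said of these compounds alone.

In a functional assay on NCI-H460 cells (Homo sapiens) for cytotoxicity, read by MTT assay, with a stated time of 72 h (a higher number here means a weaker inhibitor, a lower number a stronger inhibitor), compound 2 `CC1CCN(Cc2ccc3nc(NC(=O)N/N=C/c4cn(Cc5cccc(Cl)c5)c5ccccc45)sc3c2)CC1` gives 280 nM, the lowest of three numbers, with compound 1 `CC1CCN(Cc2ccc3nc(NC(=O)N/N=C/c4cn(Cc5ccc(Cl)cc5Cl)c5ccccc45)sc3c2)CC1` at 1660 nM and compound 3 `CC1CCN(Cc2ccc3nc(NC(=O)N/N=C/c4c[nH]c5ccccc45)sc3c2)CC1` at 4130 nM. Compound 4 `CCN(CC)Cc1ccc2nc(NC(=O)N/N=C/c3cn(Cc4cccc(Cl)c4)c4ccccc34)sc2c1` differs from compound 2 by diethylamino in place of 4-methylpiperidin-1-yl on a saturated chain carbon bound to an aromatic carbon. The measured steps all lie elsewhere, on the aromatic nitrogen: a modest 5.9-fold lower number from compound 1 to compound 2 (0.77 log units; beyond the scatter), a modest 2.5-fold higher number from compound 1 to compound 3 (0.40 log units; beyond the scatter) and a large 15-fold higher number from compound 2 to compound 3 (1.17 log units; beyond the scatter). None of them touches this place, so they give no direct size for the change. Only a small rise, within the scatter, is therefore expected, and the estimated step is a 1.3-fold higher number from compound 2 to compound 4 (0.10 log units; within the scatter). Compound 4 is expected near 350 nM, within an estimated range of 120 nM to 1000 nM.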

Compound 4, half-maximal inhibitory concentration: 220 nM
Estimate against measurement, compound 4: 1.6-fold (0.20 log units) above; low and high end bracket the measured number.
By their numbers in this assay, from the lowest: compounds 4 and 2 (each within the scatter of the next); then compound 1; then compound 3.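

In this assay, this is the first change shown on the saturated chain carbon bound to an aromatic carbon, and a 1.3-fold lower number from compound 2 to compound 4 (0.10 log units; within the scatter) shows that, with 3-chlorobenzyl held constant, the ring of 4-methylpiperidin-1-yl is not required here to keep the number low. The open-chain diethylamino serves as well in this pair. Nothing measured here explains why the two groups read alike.

As far as these compounds go, whether a morpholine ring or a carboxylic acid would be tolerated at this place remains open. So does whether diethylamino would read the same alongside 2,4-dichlorobenzyl or hydrogen on the aromatic nitrogen.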